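A few compounds are considered here, and "the series" means these few. Any claim that something is new, unique, unknown or untested is made for them only; others in the source may bear on it.

In a functional assay on HEK293 cells for agonist activity at 5-hydroxytryptamine receptor 4 (Homo sapiens), read by cAMP accumulation (on this read-out lower numbers stand for an effect already at smaller amounts and higher numbers for an effect only at larger amounts of compound), compound 1 `CC(C)n1c(=O)n(C(=O)NCC2CCNCC2)c2ccccc21` gives 15.9 nM, compound 2 `COc1ccc2[nH]cc(C(=O)NCC3CCNCC3)c2c1` gives 6310 nM, and compound 3 `CCCCCN1CCC(NC(=O)c2cc(Cl)c(N)cc2OC)CC1` gives 25.1 nM. Of these three numbers compound 3 holds the second highest place: next to it stands compound 1, whose number is lower by an amount that lies within the scatter of repeated measurements, while compound 2 sits far away with a number that is higher by an amount well beyond that scatter. Compound 3 and compound 1 thus cannot be told apart on these data, and compound 2 is clearly set apart from both.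

Compound 4 `COc1cc(N)c(Cl)cc1C(=O)NC1CCN(CCN2CCCCC2)CC1` is not yet measured. It differs from compound 3 in one place: piperidin-1-yl in place of propyl on a saturated chain carbon, two bonds along the chain from an amine nitrogen in a ring. Within the data shown here, no pair of measured compounds shows what such a swap does, so the expectation rests on compound 3 alone. Because compound 3 gives 25.1 nM, compound 4 is expected to stay close to it, with a step of a 1.3-fold lower number from compound 3 to compound 4 (0.10 log units; within the scatter) that is expected to lie within the scatter. Compound 4 is therefore estimated at 20 nM, in a range from 5 nM to 80 nM.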

Compound 4, half-maximal effective concentration: 100 nM
Compound 4: middle estimate off by 5.0-fold (0.70 log units), on the low side, outside the stated range (above it).
By their numbers in this assay, from the lowest: compounds 1 and 3 (each within the scatter of the next); then compound 4; then compound 2.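

In this assay putting piperidin-1-yl in place of propyl on a saturated chain carbon, two bonds along the chain from an amine nitrogen in a ring, gives a 4.0-fold higher number from compound 3 to compound 4 (0.60 log units; beyond the scatter) and so calls for a larger amount of compound. Among these compounds, this is the first comparison here between compounds that differ in one place, and it shows that the number responds to a change at this position, though the step is only modest. No measurement shown here explains the step.

One swap cannot separate the effect of the added ring from that of the added nitrogen, since both enter together. As far as these compounds go, it remains open whether a plain hexyl chain, an open diethylamino group or a morpholin-4-yl ring at the same place would behave like propyl or like piperidin-1-yl.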